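This account rests on a few compounds, and the source may have more. Where it says the series, first, only, none or still open, it means among the compounds named here.

Measured so far in a functional assay on HCT-116 cells (Homo sapiens) for cytotoxicity, read by MTT assay, with a stated time of 3 days; a higher number here means a weaker inhibitor, a lower number a stronger inhibitor:
compound 1 `CC(C)N1Cc2ccc(/C=N/Nc3ncnc4sc(C(C)(C)C)cc34)cc2C1` gives 0.206 ug/mL
compound 2 `CC(C)(C)c1cc2c(N/N=C/c3ccc(CO)cc3)ncnc2s1` gives 0.665 ug/mL
compound 3 `CC(C)(C)c1cc2c(N/N=C/c3ccc4c(c3)CNC4)ncnc2s1` gives 0.111 ug/mL

Compound 2 (0.665 ug/mL) has the highest number of the three, beyond the scatter from both others. Compound 4 `CN(C)S(=O)(=O)c1ccc(/C=N/Nc2ncnc3sc(C(C)(C)C)cc23)cc1` differs from it by one change dimethylsulfamoyl in place of hydroxymethyl on an aromatic carbon with dimethylsulfamoyl in place of hydroxymethyl on an aromatic carbon, para to a large group. For the measured compounds named here, the only measured step (a 1.9-fold lower number from compound 1 to compound 3 (0.27 log units; within the scatter)) lies within the scatter and concerns an amine nitrogen in a ring, so it gives no direct guide here. Going by the values given here, no measured step covers this place. In this assay no change beyond the scatter is therefore expected, and the estimated step is small (a 1.5-fold lower number from compound 2 to compound 4 (0.17 log units; within the scatter)). The estimated value for compound 4 is 0.45 ug/mL with 0.12 ug/mL to 1.5 ug/mL as its expected range.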

Compound 4, half-maximal inhibitory concentration: 1.42 ug/mL
Estimate against measurement, compound 4: 3.2-fold (0.50 log units) below; low and high end bracket the measured number.
By their numbers in this assay, from the lowest: compounds 3 and 1 (each within the scatter of the next); then compound 2; then compound 4.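

In this assay, the aromatic carbon para to a large group responds to substitution: dimethylsulfamoyl in place of hydroxymethyl gives a 2.1-fold higher number from compound 2 to compound 4 (0.33 log units; beyond the scatter), a modest step and the only one shown at this position. The change removes a hydrogen-bond donor and adds heavy atoms, but this single pair cannot separate those differences. Nothing shown bears on the cause of the step.

Open, on these data alone, is whether an amine or a carboxylic acid on this carbon would give a lower or higher number. Also open, as far as these compounds go, is whether an unsubstituted sulfamoyl group would behave like dimethylsulfamoyl.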